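Swapping the aryl group on the triazole of compound 1

The source may report more compounds than this note shows. Statements on the series, on what has been measured and on what is new or still open speak of the compounds shown alone.

Compound 1 `CC1(C)[C@H]2CC[C@]1(C)N(Cc1cn(-c3ccccc3C#N)nn1)C(=O)C2` is the starting point. In a functional assay on SGC-7901 cells (Homo sapiens) for inhibition, read by MTT assay, with a stated time of 24 h (on this read-out higher numbers stand for weaker inhibition and lower numbers for stronger inhibition), compound 1 gives 260 nM, the lowest of the three numbers shown, though all three sit within the scatter of one another. Compound 2 `CC1(C)[C@H]2CC[C@]1(C)N(Cc1cn(-c3ccc(F)cc3)nn1)C(=O)C2` gives 500 nM and compound 3 `Cc1ccccc1-n1cc(CN2C(=O)C[C@@H]3CC[C@@]2(C)C3(C)C)nn1` gives 350 nM. The change to compound 4 `COc1cccc(-n2cc(CN3C(=O)C[C@@H]4CC[C@@]3(C)C4(C)C)nn2)c1` is 3-methoxyphenyl in place of 2-cyanophenyl on an aromatic nitrogen. The closest guides are the aryl swaps already seen: a 1.9-fold higher number from compound 1 to compound 2 (0.28 log units; within the scatter), a 1.3-fold higher number from compound 1 to compound 3 (0.13 log units; within the scatter) and a 1.4-fold lower number from compound 2 to compound 3 (0.15 log units; within the scatter). None of these moved the number beyond the scatter, so no step beyond the scatter is expected here either, with at most a slight drift upward. Compound 4 is therefore estimated at 400 nM, within 180 nM to 900 nM, which would mean an expected 1.5-fold higher number from compound 1 to compound 4 (0.19 log units; within the scatter).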

Compound 4, half-maximal inhibitory concentration: 590 nM
For compound 4 the middle estimate is 1.5-fold (0.17 log units) below the measured one, within the range that was stated.
By their numbers in this assay, from the lowest: compounds 1, 3, 2 and 4 (each within the scatter of the next, the first and the last beyond it).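

Compound 4 carries 3-methoxyphenyl on the aromatic nitrogen where compound 1 carries 2-cyanophenyl, and this gives the only step among these aryl swaps that passes the scatter in this assay: a 2.3-fold higher number from compound 1 to compound 4 (0.36 log units; beyond the scatter), and a modest one. The other two steps stay inside it, a 1.7-fold higher number from compound 3 to compound 4 (0.23 log units; within the scatter) and a 1.2-fold higher number from compound 2 to compound 4 (0.07 log units; within the scatter), so compound 4 stands apart from compound 1 alone. Nothing at hand gives a reason for this step.

All four compounds carry a substituted phenyl on this nitrogen. From the compounds shown here alone, how an aminophenyl, a carboxylic acid on the phenyl or a pyridine ring would read remains open.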